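Methoxy for hydroxy on the pyrimidine of compound 1

The source may report more compounds than this note shows. Statements on the series, on what has been measured and on what is new or still open speak of the compounds shown alone.

Compound 1 `Cc1cc(O)nc(NC(=S)NC(=O)c2c(-c3ccc(Cl)cc3Cl)noc2C)n1` gives 46.7% in a functional assay on the whole organism for inhibition, with Chenopodium ficifolium as the target, with a stated time of 72 h, tested at 100 mg/L (on this read-out lower numbers stand for less inhibition of growth and higher numbers for more inhibition of growth at the one concentration tested), the lowest of the three numbers recorded in the series. Compound 2 `CSc1cc(C)nc2n/c(=N/C(=O)c3c(-c4ccc(Cl)cc4Cl)noc3C)sn12` gives 75.2% and compound 3 `COc1cc(Cl)nc2n/c(=N/C(=O)c3c(-c4ccc(Cl)cc4Cl)noc3C)sn12` gives 65.9%; both stand beyond the scatter above compound 1, but neither differs from compound 1 in one place, so the two values show only where they lie. Compound 4 `COc1cc(C)nc(NC(=S)NC(=O)c2c(-c3ccc(Cl)cc3Cl)noc2C)n1` is compound 1 with methyl in place of hydrogen on an oxygen on an aromatic ring. Within the data shown here, no measured pair in this set carries that change, so its size is not known here. The expected step of a number 8.3 percentage points higher from compound 1 to compound 4 (within the scatter) is a small rise, possibly none beyond the scatter. Compound 4 is therefore estimated at 55%, with a range from 32% to 78%.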

Compound 4, percent growth inhibition at one concentration: 59.8%
Beside the measured number, compound 4's estimate is 4.8 percentage points below it; measured number inside the range.
By their numbers in this assay, from the lowest: compound 1; then compounds 4, 3 and 2 (each within the scatter of the next, the first and the last beyond it).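

Among these compounds, this is the first one-place comparison: in this assay the change from hydroxy to methoxy gives a number 13.1 percentage points higher from compound 1 to compound 4 (beyond the scatter) at this position. The hydrogen on this oxygen is therefore not needed for the growth inhibition seen here, and methyl in its place raises the read-out. Nothing at hand bears on the reason for this step.

On these data alone, whether ethoxy, a longer chain on this oxygen, or an amine in place of the oxygen would keep or extend this rise remains open.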